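A few compounds are considered here, and "the series" means these few. Any claim that something is new, unique, unknown or untested is made for them only; others in the source may bear on it.

Compound 1 `Cn1cnnc1S(=O)(=O)N1CCC(CNC(=O)c2ccc(Cl)cc2Cl)(CC2CC2)CC1` is the starting point. In an assay on JAR cells for inhibition of sodium- and chloride-dependent glycine transporter 1 (Homo sapiens), read by scintillation counting, with a stated time of 3 h (on this read-out higher numbers stand for weaker inhibition and lower numbers for stronger inhibition), compound 1 gives 124 nM. Among the compounds with values here, this stands at the low end of the two numbers measured so far, though the gap to the other compound lies within the usual scatter, so the two cannot be told apart on potency. That other compound, compound 2 `Cn1nncc1S(=O)(=O)N1CC(CNC(=O)c2ccc(Cl)cc2Cl)(CC2CC2)C1`, carries a different central ring and a differently joined triazole, and in this assay compound 2 gives 185 nM.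

The unmeasured compound 3 `Cn1cc(S(=O)(=O)N2CCC(CNC(=O)c3ccc(Cl)cc3Cl)(CC3CC3)CC2)nn1` differs from compound 1 in one place: 1-methyl-1H-1,2,3-triazol-4-yl in place of 4-methyl-4H-1,2,4-triazol-3-yl on a sulfonyl sulfur. The atoms are the same and are only joined differently, so the size of the group and what it carries stay unchanged. Within the data shown here, no measured pair shows what this swap alone does here. Since compound 2, whose triazole is also joined differently on its sulfonyl sulfur, gives 185 nM, a step no larger than the scatter is expected, in no particular direction. The step from compound 1 to compound 3 is therefore expected to be a 1.2-fold higher number from compound 1 to compound 3 (0.08 log units; within the scatter). Compound 3 is estimated at 150 nM, with a range from 60 nM to 400 nM.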

Compound 3, half-maximal inhibitory concentration: 32 nM
The estimate for compound 3 lay 4.7-fold (0.67 log units) above the measured number; measured number below the stated range.
By their numbers in this assay, from the lowest: compound 3; then compounds 1 and 2 (each within the scatter of the next).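

The result shows that the sulfonyl sulfur is sensitive to how the atoms of the triazole are joined: in this assay, changing 4-methyl-4H-1,2,4-triazol-3-yl to 1-methyl-1H-1,2,3-triazol-4-yl gives a 3.9-fold lower number from compound 1 to compound 3 (0.59 log units; beyond the scatter) and this step lies beyond the usual scatter. The two groups have the same heavy atoms, the same counts of hydrogen-bond donors and acceptors, and no net charge, so those counts alone do not separate them; the arrangement of the same atoms is enough to change the number. Compound 2 could not show this, since it differs from compound 1 in its central ring as well as in its triazole, and nothing available here explains the step.

Going by these compounds, it remains open whether the 1-methyl-1H-1,2,3-triazol-4-yl group would give a similar step on another core, such as that of compound 2. On these data alone, it is also open how the number would respond to a longer chain such as ethyl in place of the methyl on the triazole, or to a phenyl ring in place of the triazole on the sulfonyl sulfur.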